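Side-chain amine variation on the core of compound 2

The source may report more compounds than this note shows. Statements on the series, on what has been measured and on what is new or still open speak of the compounds shown alone.

Compound 2 `CN(C)CCn1c(=O)sc2cc(S(=O)(=O)N(C)c3cccc4ccccc34)ccc21` gives 0% in an assay on HEK293 cells for displacement of a labelled ligand from 5-hydroxytryptamine receptor 6 (Homo sapiens), read by radioligand binding, with a stated time of 60 min, tested at 100 nM (a lower number here means less inhibition, a higher number more inhibition at the concentration tested (going by the name of the read-out)), which is the lowest of the two numbers measured; its nearest neighbour is compound 1 `CN(C)CCn1c(=O)sc2cc(S(=O)(=O)N(C)c3ccccc3)ccc21`, which in this assay gives 5%, and the step of a number 5 percentage points lower from compound 1 to compound 2 (within the scatter) lies within the scatter. Compound 3 `CN(c1cccc2ccccc12)S(=O)(=O)c1ccc2c(c1)sc(=O)n2CCN1CCCCC1` is not yet measured. It differs from compound 2 by piperidin-1-yl in place of dimethylamino on a saturated chain carbon, two bonds along the chain from an aromatic nitrogen. Within the data shown here, no measured step touches this part of the molecule: the only step known, a number 5 percentage points lower from compound 1 to compound 2 (within the scatter), concerns the group on the sulfonamide nitrogen and tells nothing about the chain amine. With both measured compounds near the bottom of the read-out and no change beyond the scatter seen so far, no step beyond the scatter is expected for compound 3, that is a number 5 percentage points higher from compound 2 to compound 3 (within the scatter). The estimate for compound 3 in this assay is therefore 5%, with a range from -8% to 20%.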

Compound 3, a percentage reported as inhibition, at one concentration (the size of the read-out at that concentration, not a potency): 14%
The estimate for compound 3 lay 9 percentage points below the measured number; low and high end bracket the measured number.
By their numbers in this assay, from the lowest: compounds 2, 1 and 3 (each within the scatter of the next, the first and the last beyond it).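

Among these compounds, the chain amine is the first place where a change exceeds the scatter: piperidin-1-yl in place of dimethylamino gives a number 14 percentage points higher from compound 2 to compound 3 (beyond the scatter) in this assay and stands apart from the only earlier step, on the sulfonamide nitrogen, which stayed within the scatter. This position therefore responds to the amine it carries, although compound 3 at 14% is still a low reading and the step is modest. Nothing at hand accounts for the step.

Open, as far as these compounds go, is whether the ring of piperidin-1-yl matters or only the added carbons, which a pyrrolidin-1-yl, morpholin-4-yl or diethylamino group on the same chain would help separate. Also open, from the compounds shown here alone, is whether a longer chain between the aromatic nitrogen and the amine would change the reading.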